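Side chain on the ring nitrogen: cyclohexylmethyl to acetylmethyl

The source may report more compounds than this note shows. Statements on the series, on what has been measured and on what is new or still open speak of the compounds shown alone.

Three compounds share one core and differ only in the chain on the aromatic nitrogen. Compound 1 `CCCn1nc(-c2cccnc2)c2ccccc2c1=O` carries the shortest chain; in an assay on isolated protein (Oryctolagus cuniculus) with Thromboxane-A synthase (Homo sapiens) as the target, tested at 1 uM (on this read-out lower numbers stand for less inhibition and higher numbers for more inhibition at the one concentration tested (going by the name of the read-out)), compound 1 gives 86%. Compound 2 `CCCCn1nc(-c2cccnc2)c2ccccc2c1=O` gives 91%, and compound 3 `O=c1c2ccccc2c(-c2cccnc2)nn1CC1CCCCC1` gives 98%. Compound 3 stands highest of the three, though only the gap to compound 1 is beyond the scatter: a number 12 percentage points higher from compound 1 to compound 3 (beyond the scatter), while a number 7 percentage points higher from compound 2 to compound 3 (within the scatter) and a number 5 percentage points higher from compound 1 to compound 2 (within the scatter).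

Compound 4 `CC(=O)Cn1nc(-c2cccnc2)c2ccccc2c1=O` is the next point. Its difference from compound 3 is acetyl in place of cyclohexyl on a saturated chain carbon bound to an aromatic nitrogen. For the measured compounds named here, the change undoes the growth of the chain that produced the step from compound 1 to compound 3, and it brings in a hydrogen-bond acceptor on a chain of three heavy atoms, for which no earlier compound gives a reading.

Going by the values given here, the steps that bear on it, compound 1 to compound 3 and compound 2 to compound 3, both rose as the chain grew. Removing cyclohexyl is therefore expected to lower the number, likely by a modest amount beyond the scatter, with added uncertainty from the acetyl group itself. Compound 4 is estimated at 75%, between 50% and 92%, an expected step of a number 23 percentage points lower from compound 3 to compound 4 (beyond the scatter).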

Compound 4, a percentage reported as inhibition, at one concentration (the size of the read-out at that concentration, not a potency): 13%
Compound 4: middle estimate off by 62 percentage points, on the high side; the measured number lies below the stated range.
By their numbers in this assay, from the lowest: compound 4; then compounds 1, 2 and 3 (each within the scatter of the next, the first and the last beyond it).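

At this position, on a saturated chain carbon bound to an aromatic nitrogen, acetyl is not interchangeable with the groups seen so far: in this assay the change gives a number 85 percentage points lower from compound 3 to compound 4 (beyond the scatter), alongside a number 78 percentage points lower from compound 2 to compound 4 (beyond the scatter) and a number 73 percentage points lower from compound 1 to compound 4 (beyond the scatter). These large steps dwarf those among compounds 1, 2 and 3, and the last of them shows that the loss of the cyclohexyl ring alone cannot account for the fall, since compound 1, with ethyl in the same place and no ring in its chain, stands far higher than compound 4. Nothing available explains the drop, so the result stays an observation about the acetyl group at this place.

For the compounds shown here, with compound 4 the only member carrying a hydrogen-bond acceptor in the chain, it remains open whether the carbonyl itself goes with the low number or whether any oxygen in the chain would do the same, which a 2-hydroxypropyl or a 2-methoxyethyl chain would help to separate. Also open, from the compounds shown here alone, is how an amine or a carboxylic acid at the end of the chain would read, and whether a longer chain ending in a ketone would recover the number.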